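Dichloro Substitution on a Benzyl Group in a Cytotoxicity Screen

A few compounds are considered here, and "the series" means these few. Any claim that something is new, unique, unknown or untested is made for them only; others in the source may bear on it.

Measured compounds:
compound 1 `O=S1(=O)N=C(OCc2ccccc2)c2ccccc2N1Cc1ccccc1` — 200000 nM
compound 2 `O=C1c2ccccc2N(Cc2ccccc2Cl)S(=O)(=O)N1Cc1ccccc1Cl` — > 20000 nM

Of the compounds shown here, two have been tested in a functional assay on HEL cells (Homo sapiens); a higher number here means that more compound is tolerated, a lower number that less compound is tolerated. Among the compounds with values here, compound 1 is the only one with a full number: it gives 200000 nM in this assay. Compound 2 returns only a limit of the assay, > 20000 nM, so it shows no value of its own; this is the limit described in the limit of > 20000 nM in this assay, at which 1 of the 2 values shown sits. Within the data shown here, no step between two measured compounds that differ in a single place is available.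

Compound 3 `O=S1(=O)N=C(OCc2ccccc2)c2ccccc2N1Cc1ccc(Cl)c(Cl)c1` has not yet been measured. Relative to compound 1 it carries 3,4-dichlorophenyl in place of phenyl on a saturated chain carbon bound to a sulfonamide nitrogen in a ring. Among the measured compounds shown here, with no measured step to lean on, the account can only expect a modest change in this assay, if any, running toward a lower minimum cytotoxic concentration than compound 1 shows, and possibly no further than the usual scatter. Compound 3 is therefore estimated at 100000 nM in this assay, between 30000 nM and 300000 nM, an expected step of a 2.0-fold lower number from compound 1 to compound 3 (0.30 log units; within the scatter).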

Compound 3, minimum cytotoxic concentration: 200000 nM
Estimate against measurement, compound 3: 2.0-fold (0.30 log units) below, within the range that was stated.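

Within the data shown here, putting 3,4-dichlorophenyl in place of phenyl on a saturated chain carbon bound to a sulfonamide nitrogen in a ring gives no change at the digits printed from compound 1 to compound 3 (within the scatter) in this assay, and this is the first step in the set that can be read at a single place. At this place, therefore, the minimum cytotoxic concentration does not separate the benzyl group from the 3,4-dichlorobenzyl group. Nothing in the data accounts for this outcome.

The compounds shown leave open whether the same flat reading would hold with a different group on this benzyl ring, such as an amine or a carboxylic acid. They also leave open how the reading would respond to a change elsewhere on the core of compound 1, such as a longer chain in place of its other benzyl group.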